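A few compounds are considered here, and "the series" means these few. Any claim that something is new, unique, unknown or untested is made for them only; others in the source may bear on it.

Of the compounds shown here, three have been tested so far in an ADME assay on TZM cells (Homo sapiens) for cytotoxicity, read by XTT assay, with a stated time of 4 days; a lower number here means that less compound is tolerated, a higher number that more compound is tolerated. Within the data shown here, compound 1 `CC(=O)CCc1cc(C)c(Oc2cc(Nc3ccc(C#N)cc3)c(N)cc2C(F)(F)F)c(C)c1` gives 11100 nM, the only true number of the three. Compound 2 `Cc1cc(/C=C/C#N)cc(C)c1Oc1cc(Nc2ccc(C#N)cc2)c(N)cc1[N+](=O)[O-]` reads > 24400 nM, which is a limit of the assay and not a number. Compound 3 `CC(=O)/C=C/c1cc(C)c(Oc2cc(Nc3ccc(C#N)cc3)c(N)cc2C(F)(F)F)c(C)c1` reads > 8600 nM, and this too is a limit. Compound 2 therefore has a floor on the scale but no exact place on it.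

The next compound, compound 4 `Cc1cc(/C=C/C#N)cc(C)c1Oc1cc(Nc2ccc(C#N)cc2)c(N)cc1C(=O)O`, differs from compound 2 by one swap, (carboxy in place of nitro on an aromatic carbon). In words, carboxy takes the place of nitro on an aromatic carbon, para to a (4-cyanophenyl)amino group.

Among the measured compounds shown here, only one measured step exists, a step that the limit leaves unreadable from compound 1 to compound 3. It swaps 2-acetylethyl for 2-acetylethenyl, a different change from the one at hand, and it offers no size to carry over. For the measured compounds named here, no measured step involves the nitro or carboxy group, so the direction stays open, and no change beyond the usual scatter is expected. The expectation rests on compound 2 alone, whose > 24400 nM is a limit. The expected change is a step that the limit leaves unreadable from compound 2 to compound 4. For compound 4, the estimated half-maximal cytotoxic concentration is 30000 nM, within an expected range of 10000 nM to 80000 nM.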

Compound 4, half-maximal cytotoxic concentration: 14900 nM
Compound 4: middle estimate off by 2.0-fold (0.30 log units), on the high side; the range from low to high includes it.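

Carboxy in place of nitro, para to a (4-cyanophenyl)amino group, gives this position a true reading, as in this assay compound 4 gives 14900 nM. The change is an at least 1.6-fold lower number from compound 2 to compound 4 (0.21 log units; that floor lies within the scatter), so the carboxy compound reads lower by an amount that may be small or may be larger, and the floor alone does not show a real change. The step has no upper end because the value of compound 2 is a limit of the assay and not a number: the limit of > 24400 nM in this assay, at which 1 of the 4 values shown sits.

On these data alone, it remains open how far the true value of compound 2 lies from that of compound 4, and whether another group at this position, such as an amine or a methyl ester, would give a reading close to that of carboxy. Among these compounds, the same swap is also seen only with the 2-cyanoethenyl-type side chain shared by compound 2 and compound 4, so it is unknown whether it would read the same way with the 2-acetylethyl chain of compound 1 or the 2-acetylethenyl chain of compound 3.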